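Methyl step on compound 2

The compounds below may be only part of what the source reports. "The series", "measured", "known", "first", "only" and "open" are said of these compounds alone.

Measured compounds:
- compound 1 `CC(NC(=O)c1ncc([N+](=O)[O-])n1C)c1ccc(F)cc1`: > 100000 nM
- compound 2 `O=C(NCc1ccc(F)cc1)c1ncc([N+](=O)[O-])[nH]1`: > 100000 nM
- compound 3 `O=C(NCc1ccc(OC(F)(F)F)cc1)c1ncc([N+](=O)[O-])[nH]1`: 93000 nM

In a toxicity assay on HepG2 cells (Homo sapiens) for inhibition, read by resazurin assay, with a stated time of 24 h (on this read-out higher numbers stand for lower toxicity in this test and lower numbers for higher toxicity in this test), compound 2 gives > 100000 nM, which is a limit and not a number. Compound 1 gives > 100000 nM, which is also a limit. For the measured compounds named here, compound 3 gives 93000 nM, the one true number in the set. Most of the series therefore sits at the limit of > 100000 nM in this assay, at which 2 of the 3 values shown sit.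

The step under consideration leads to compound 4 `CC(NC(=O)c1ncc([N+](=O)[O-])[nH]1)c1ccc(F)cc1`. The change is methyl in place of hydrogen on a saturated chain carbon bound to an amide-type nitrogen and an aromatic carbon.

Going by the values given here, the one measured step is an at least 1.0-fold lower number from compound 2 to compound 3 (0.03 log units; that floor lies within the scatter), for trifluoromethoxy in place of fluoro on an aromatic carbon. That change lies on an aromatic carbon and not on the chain carbon, so it bears only loosely on the methyl change. Among the compounds with values here, with only this step to go on, no step beyond the scatter is expected in this assay, and neither direction is favoured.

The expected step is a number no higher from compound 2 to compound 4 (the limit leaves the size open). For compound 4 the estimated value is 100000 nM, with an expected range from 60000 nM to 150000 nM.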

Compound 4, half-maximal cytotoxic concentration: > 100000 nM
Compound 4: no number, only a limit; the forecaster's own chance of this, stated with the estimate: 75%; the middle value sits exactly at the limit.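

In this assay compound 4 gives > 100000 nM, which is a limit and not a number. No step can be read from compound 2 or from compound 1 to compound 4, because all three values are limits: the limit of > 100000 nM in this assay, at which 3 of the 4 values shown sit.

As far as these compounds go, whether either methyl change shifts the read-out at all, and in which direction, stays open.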